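Aryl variation on the ring nitrogen of the amide series

A few compounds are considered here, and "the series" means these few. Any claim that something is new, unique, unknown or untested is made for them only; others in the source may bear on it.

Measured so far in a functional assay on HOS-TE85 cells (Homo sapiens) for inhibition, read by CCK-8 assay, with a stated time of 72 h, tested at 1 uM; a higher number here means more inhibition at the concentration tested (going by the name of the read-out), a lower number less inhibition:
compound 1, `Cc1cccc(N2C(=O)CSC2c2cccc(C(=O)NCCCCc3ccccc3)c2)c1`: 96%
compound 2, `CCOc1ccccc1N1C(=O)C(C)SC1c1cccc(C(=O)NCCCCc2ccccc2)c1`: 94%
compound 3, `COc1ccccc1N1C(=O)CSC1c1cc(F)cc(C(=O)O)c1`: 0%

Compound 1 gives the highest of the three numbers; compound 2 lies within the scatter of it, so no order between the two can be stated, while compound 3 lies far beyond the scatter below both. Compound 3 differs from compound 1 in several places at once, so its gap is tied to no single change.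

Compound 4 is `COc1ccc(N2C(=O)CSC2c2cccc(C(=O)NCCCCc3ccccc3)c2)c(OC)c1`, which differs from compound 1 by 2,4-dimethoxyphenyl in place of 3-methylphenyl on an amide-type nitrogen in a ring. Going by the values given here, no single-change step among the measured compounds covers this change. Compound 2, which also carries an alkoxy-bearing aryl on the ring nitrogen, gives 94% in this assay, so the step from compound 1 to compound 4 is expected to stay within the scatter, in no clear direction. Compound 4 is estimated at 90% in this assay, within 70% to 100%, an expected step of a number 6 percentage points lower from compound 1 to compound 4 (within the scatter).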

Compound 4, a percentage reported as inhibition, at one concentration (the size of the read-out at that concentration, not a potency): 58%
Compound 4: middle estimate off by 32 percentage points, on the high side; measured number outside the range, below it.
By their numbers in this assay, from the lowest: compound 3; then compound 4; then compounds 2 and 1 (each within the scatter of the next).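

In this assay the step of a number 38 percentage points lower from compound 1 to compound 4 (beyond the scatter) comes with 2,4-dimethoxyphenyl in place of 3-methylphenyl on the amide-type nitrogen in the ring. Going by these compounds alone, this is the first change confined to one place, and it shows that the read-out at this position depends on the aryl group while the rest of compound 1 stays fixed. Nothing measured here accounts for the size of this step. Open, as far as these compounds go, is whether either methoxy group alone carries the step, and how an unsubstituted phenyl or a chlorophenyl would read at this position.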